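This account rests on a few compounds, and the source may have more. Where it says the series, first, only, none or still open, it means among the compounds named here.

Measured compounds:
compound 1 `COc1cc(NC(C)CCCNC(=O)Nc2ccc(C(F)(F)F)cc2)c2ncccc2c1` with 8400 nM in a functional assay on MIA PaCa-2 cells (Homo sapiens) for inhibition, read by MTT assay, with a stated time of 72 h; on this read-out lower numbers stand for stronger inhibition and higher numbers for weaker inhibition
compound 2 `COc1cc(NC(C)CCCNC(=O)NNC(=O)Nc2ccc(C(F)(F)F)cc2)c2ncccc2c1` with 19000 nM in this assay

Compound 1 stands at the lowest number of the two measured here. Its nearest neighbour is compound 2, whose number is higher, and the gap between the two lies beyond the usual scatter of repeated measurements, so compound 1 reads as the stronger inhibitor of the pair.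

The step under consideration runs from compound 1 to the unmeasured compound 3 `COc1cc(NC(C)CCCNC(=O)Nc2cccc(O)c2)c2ncccc2c1`. The change is 3-hydroxyphenyl in place of 4-(trifluoromethyl)phenyl on an amide-type nitrogen. The shared core and the chain are kept; only the aryl group on the amide-type nitrogen, whose other neighbour is a carbonyl carbon, is exchanged.

Among the measured compounds shown here, no measured pair in this set differs in exactly this way, so there is no directly comparable step to lean on. The account therefore expects a modest step from compound 1 to compound 3 in this assay, a 1.4-fold higher number from compound 1 to compound 3 (0.15 log units; within the scatter), toward a somewhat higher number, with a real chance of no change beyond the scatter. The estimate for compound 3 is 12000 nM, within a range from 4000 nM to 40000 nM.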

Compound 3, half-maximal inhibitory concentration: 46000 nM
Compound 3: middle estimate off by 3.8-fold (0.58 log units), on the low side; the measured number lies above the stated range.
By their numbers in this assay, from the lowest: compound 1; then compound 2; then compound 3.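

In this assay, the exchange of 4-(trifluoromethyl)phenyl for 3-hydroxyphenyl on the amide-type nitrogen gives a 5.5-fold higher number from compound 1 to compound 3 (0.74 log units; beyond the scatter), a move toward weaker inhibition, so the number responds to the aryl group held at this position. Among the compounds shown here, compound 1 and compound 2 both carry 4-(trifluoromethyl)phenyl and so could say nothing about this group, whereas compound 3 is the first here in which it is exchanged, and the result is the highest number of the three. Nothing on hand explains why this exchange raises the number.

From the compounds shown here alone, the exchange alters both the substituent and its numbered place on the ring in a single step, so it remains open whether 4-hydroxyphenyl or 3-(trifluoromethyl)phenyl on this nitrogen would stand closer to compound 1 or to compound 3. Also open, going by these compounds, is how an unsubstituted phenyl, or a ring bearing an amine or a carboxylic acid, would read at the same position in this assay, with the shared core and the chain kept.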